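Methylation of a phenol on a second core

The source may hold more compounds than are shown below. What is called first, only, known or untested is meant among the compounds shown, and "the series" means these compounds.

Three enaminone-type compounds were measured in a functional assay on HT-29 cells (Homo sapiens) for antiproliferative activity, read by MTT assay, with a stated time of 48 h; on this read-out higher numbers stand for weaker inhibition and lower numbers for stronger inhibition. Compound 1, `COc1ccc(-c2nn(-c3ccccc3)cc2C(=O)/C=C\Nc2ccc(O)cc2)cc1`, gives 2460 nM. Compound 2, `COc1ccc(N/C=C\C(=O)c2cn(-c3ccccc3)nc2-c2ccc(OC)cc2)cc1`, gives 8760 nM. Compound 2 differs from compound 1 by methyl in place of hydrogen on an oxygen on an aromatic ring, and this change made a 3.6-fold higher number from compound 1 to compound 2 (0.55 log units; beyond the scatter). Compound 3, `COc1cc(-c2nn(-c3ccccc3)cc2C(=O)/C=C\Nc2ccc(O)cc2)cc(OC)c1OC`, gives 2500 nM; its value and that of compound 1 lie within the scatter of each other. The difference between the cores of compound 1 and compound 3 is not broken down here.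

Compound 4, `COc1ccc(N/C=C\C(=O)c2cn(-c3ccccc3)nc2-c2cc(OC)c(OC)c(OC)c2)cc1`, has not yet been measured in this assay. Among the compounds with values here, it differs from compound 3 by methyl in place of hydrogen on an oxygen on an aromatic ring, which is the same change as the one from compound 1 to compound 2, at a place described in the same words. If that change behaves on the core of compound 3 as it did on the core of compound 1, where it gave a 3.6-fold higher number from compound 1 to compound 2 (0.55 log units; beyond the scatter), a step of similar size is expected here: the estimated step from compound 3 to compound 4 is a 3.4-fold higher number from compound 3 to compound 4 (0.53 log units; beyond the scatter). This expectation rests on one pair only, compound 1 and compound 2, so a wider range is carried with it. Compound 4 is therefore estimated at 8500 nM, with a range from 3200 nM to 22000 nM, in this assay.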

Compound 4, half-maximal inhibitory concentration: 5780 nM
Compound 4: the middle estimate sits 1.5-fold (0.17 log units) above what was measured; low and high end bracket the measured number.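

In this assay, methyl in place of hydrogen on an oxygen on an aromatic ring moved the number in the same direction on the second core, giving a 2.3-fold higher number from compound 3 to compound 4 (0.36 log units; beyond the scatter), and the two steps do not differ beyond what repeated measurement allows: the same change on two cores in this assay, a 3.6-fold higher number (0.55 log units; beyond the scatter) from compound 1 to compound 2 and a 2.3-fold higher number (0.36 log units; beyond the scatter) from compound 3 to compound 4, 1.5-fold (0.19 log units) apart, within the scatter of two such steps. For these two cores, then, the change from 4-hydroxyphenyl to 4-methoxyphenyl carried over in direction and, within the scatter, in size, while 3,4,5-trimethoxyphenyl in place of 4-methoxyphenyl on an aromatic carbon, with a 1.5-fold lower number from compound 2 to compound 4 (0.18 log units; within the scatter), also stays within the scatter. This rests on two cores only, so it does not show that the step would hold on any other core in the series, and it does not explain why the methoxy compounds give the higher numbers.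

The compounds shown leave open whether a longer chain on that oxygen, such as ethyl, or an amine in place of the hydroxy group would follow the same step. They also leave open whether the step would persist on a core carrying a chloro group instead of the methoxy groups.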